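Shortening the hydroxamate linker from compound 2 to compound 3

This account rests on a few compounds, and the source may have more. Where it says the series, first, only, none or still open, it means among the compounds named here.

Compound 1 `C#CCN(C)Cc1cccc(NS(=O)(=O)c2cccc(/C=C/C(=O)NO)c2)c1`: 1230 nM
Compound 2 `C#CCN(C)Cc1ccc(NCc2ccc(/C=C/C(=O)NO)cc2)cc1`: 750 nM

Among the compounds with values here, in a functional assay on PC-3 cells (Homo sapiens) for inhibition, read by MTT assay, with a stated time of 48 h (a lower number here means a stronger inhibitor of growth, a higher number a weaker inhibitor of growth), compound 2 gives 750 nM, the lowest of the two numbers measured so far; compound 1 gives 1230 nM, a gap that stays within the scatter. Compound 3 `C#CCN(C)Cc1ccc(NCc2ccc(C(=O)NO)cc2)cc1` has not been measured. It differs from compound 2 by hydroxycarbamoyl in place of 2-(hydroxycarbamoyl)ethenyl on an aromatic carbon. Within the data shown here, no measured pair shows this change, so the step from compound 2 to compound 3 is expected to be modest and toward a higher number, beyond the scatter, a 3.3-fold higher number from compound 2 to compound 3 (0.52 log units; beyond the scatter). Compound 3 is therefore estimated at 2500 nM, in a range from 900 nM to 7000 nM.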

Compound 3, concentration for 50% growth inhibition: > 10000 nM
Compound 3 gave a limit, no number (the forecaster's own chance of this, stated with the estimate: 5%); at least 4.0-fold (0.60 log units) between middle value and limit.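

In this assay, hydroxycarbamoyl in place of 2-(hydroxycarbamoyl)ethenyl on this aromatic carbon gives an at least 13-fold higher number from compound 2 to compound 3 (1.12 log units; beyond the scatter), the only single-place change shown so far. The step is large, so at this position, para to a large group, the growth inhibition of compound 2 does not survive removal of the ethenyl part. The step rests on a limit and not on a number, so its full size stays unfixed: the limit of > 10000 nM in this assay, at which 1 of the 3 values shown sits.

As far as these compounds go, it remains open whether a saturated ethyl chain ending in hydroxycarbamoyl would match compound 2. Also open, from the compounds shown here alone, is how a longer chain ending in hydroxycarbamoyl, or a carboxylic acid at this carbon, would compare.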